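Carbamate branching in the bis-trimethoxybenzoyl piperazine series

The source may report more compounds than this note shows. Statements on the series, on what has been measured and on what is new or still open speak of the compounds shown alone.

Measured so far in a functional assay (Oryctolagus cuniculus) for inhibition of platelet-activating factor receptor (Cavia porcellus); on this read-out lower numbers stand for stronger inhibition and higher numbers for weaker inhibition:
compound 1 `CCCCCC(=O)OCC1CN(C(=O)c2cc(OC)c(OC)c(OC)c2)CCN1C(=O)c1cc(OC)c(OC)c(OC)c1` gives 290 nM
compound 2 `COc1cc(C(=O)N2CCN(C(=O)c3cc(OC)c(OC)c(OC)c3)C(COC(=O)CC(C)(C)C)C2)cc(OC)c1OC` gives 120 nM
compound 3 `CCC(C)(C)NC(=O)OCC1CN(C(=O)c2cc(OC)c(OC)c(OC)c2)CCN1C(=O)c1cc(OC)c(OC)c(OC)c1` gives 320 nM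

Compound 3 sits at the highest number of the three, with compound 1 within the scatter of it and compound 2 the furthest away (a 2.7-fold higher number from compound 2 to compound 3 (0.43 log units; beyond the scatter)). Compound 4 `COc1cc(C(=O)N2CCN(C(=O)c3cc(OC)c(OC)c(OC)c3)C(COC(=O)NCCC(C)C)C2)cc(OC)c1OC` keeps every atom of compound 3 and changes only the group on the carbamate nitrogen: isopentyl in place of 1,1-dimethylpropyl on an amide-type nitrogen. Among the compounds with values here, the one step that speaks to branching on a chain carbon is a 2.4-fold lower number from compound 1 to compound 2 (0.38 log units; beyond the scatter), where more branching gave a lower number; compound 4 removes branching instead. On this assay the step is therefore expected to go in the direction of a higher number, around a 1.4-fold higher number from compound 3 to compound 4 (0.15 log units; within the scatter), small and close to the scatter. Compound 4 is thus estimated at 450 nM, with a range from 200 nM to 1000 nM.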

Compound 4, half-maximal inhibitory concentration: 140 nM
Estimate against measurement, compound 4: 3.2-fold (0.51 log units) above; the measured number lies below the stated range.
By their numbers in this assay, from the lowest: compounds 2 and 4 (each within the scatter of the next); then compounds 1 and 3 (each within the scatter of the next).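

In this assay, isopentyl in place of 1,1-dimethylpropyl on the amide-type nitrogen gives a 2.3-fold lower number from compound 3 to compound 4 (0.36 log units; beyond the scatter) at an unchanged count of heavy atoms, so the shape of this chain counts here. Isopentylamino in place of neopentyl on the carbonyl carbon gives a 1.2-fold higher number from compound 2 to compound 4 (0.07 log units; within the scatter) and in place of pentyl gives a 2.1-fold lower number from compound 1 to compound 4 (0.32 log units; beyond the scatter), so the carbamate nitrogen alone does not set the number, as compound 3 and compound 4 both carry it. No evidence here bears on the reason for this difference.

Still open, on these data alone, is how a shorter chain such as ethyl, a ring such as cyclopentyl, or a chain ending in an amine would read on this nitrogen.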